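From Fluoro to Nitro at the Assay Limit

A few compounds are considered here, and "the series" means these few. Any claim that something is new, unique, unknown or untested is made for them only; others in the source may bear on it.

Compound 1 `CCOC(=O)c1c(-c2cccc(OC)c2)[nH]c2cc(OC)ccc2c1=O` gives > 21500 nM as a limit
Compound 2 `CCOC(=O)c1c(-c2cccc(OC(F)(F)F)c2)[nH]c2cc(OC)ccc2c1=O` gives > 21500 nM as a limit
Compound 3 `CCOC(=O)c1c(-c2cccc(F)c2)[nH]c2cc(OC)ccc2c1=O` gives > 21500 nM as a limit

In an ADME assay on BJ cells (Homo sapiens) for cytotoxicity, read by luminescence, with a stated time of 72 h (on this read-out lower numbers stand for an effect already at smaller amounts and higher numbers for an effect only at larger amounts of compound), compound 3 gives > 21500 nM as a limit and not a number. It shares that position with the other two compounds (the limit of > 21500 nM in this assay, at which 3 of the 3 values shown sit) and so has no rank among them. Compound 4 `CCOC(=O)c1c(-c2cccc([N+](=O)[O-])c2)[nH]c2cc(OC)ccc2c1=O` carries nitro in place of fluoro on an aromatic carbon and is otherwise the same. Two measured steps end at the fluoro group of compound 3: a step that the two limits leave unreadable from compound 1 to compound 3 and a step that the two limits leave unreadable from compound 2 to compound 3 are the closest guides, and a step that the two limits leave unreadable from compound 1 to compound 2 links their starting points. None of these has a readable size, so no step beyond the scatter is expected in this assay and neither direction is favoured. The estimated move is a step that the limit leaves unreadable from compound 3 to compound 4 in this expectation. For compound 4 the expected value is 30000 nM with a range from 12000 nM to 60000 nM and a report as a limit is the likeliest outcome.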

Compound 4, half-maximal effective concentration: > 21500 nM
Compound 4: no number, only a limit; the forecaster's own chance of this, stated with the estimate: 80%; the middle value is on the limit's open side.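

In this assay, no step can be read between compound 4 and compound 1, compound 2 or compound 3, because each gives a limit and not a number: the limit of > 21500 nM in this assay, at which 4 of the 4 values shown sit.

The compounds shown leave open at what concentration any of the four would affect these cells, and whether swapping these groups changes that concentration.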